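Aryl variation on the acylhydrazone of the diaryl ether series

The source may hold more compounds than are shown below. What is called first, only, known or untested is meant among the compounds shown, and "the series" means these compounds.

Measured so far:
compound 1, `CN(C)CCn1cnnc1-c1cc(Oc2ccc(NC(=O)N/N=C/c3c(Cl)cccc3Cl)cc2F)ccn1`: 350 nM
compound 2, `COc1ccc(OC)c(/C=N/NC(=O)Nc2ccc(Oc3ccnc(-c4nncn4CCN(C)C)c3)c(F)c2)c1`: 2930 nM
compound 3, `COc1ccc(/C=N/NC(=O)Nc2ccc(Oc3ccnc(-c4nncn4CCN(C)C)c3)c(F)c2)c(OC)c1`: 1570 nM

All three were run in a functional assay on NCI-H460 cells (Homo sapiens) for cytotoxicity, read by MTT assay, with a stated time of 72 h; a lower number here means a stronger inhibitor, a higher number a weaker inhibitor. Compound 3 stands second highest of the three numbers in this assay; its nearest neighbour is compound 2, and the two differ only by a 1.9-fold lower number from compound 2 to compound 3 (0.27 log units; within the scatter). Against compound 1 the gap is larger, a 4.5-fold higher number from compound 1 to compound 3 (0.65 log units; beyond the scatter), and the parallel step an 8.4-fold higher number from compound 1 to compound 2 (0.92 log units; beyond the scatter) points the same way: both dimethoxyphenyl variants give higher numbers than the dichlorophenyl parent.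

Compound 4, `CN(C)CCn1cnnc1-c1cc(Oc2ccc(NC(=O)N/N=C/c3ccccc3O[N+](=O)[O-])cc2F)ccn1`, is next. The change from compound 3 is 2-(nitrooxy)phenyl in place of 2,4-dimethoxyphenyl on a carbon with a double bond to nitrogen. For the measured compounds named here, none of the measured steps covers this group; the two that bear on the same position show that replacing one aryl with another moves this assay by modest amounts in either direction, and that the two dimethoxy isomers sit within the scatter of each other. Going by the values given here, with no precedent for the nitrooxy group, the expected step of a 1.7-fold lower number from compound 3 to compound 4 (0.24 log units; within the scatter) is taken as small, leaning toward a lower number but not firmly beyond the scatter. Compound 4 is therefore estimated at 900 nM in this assay, with a range of 300 nM to 3000 nM.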

Compound 4, half-maximal inhibitory concentration: 1270 nM
Compound 4: middle estimate off by 1.4-fold (0.15 log units), on the low side; measured number inside the range.
By their numbers in this assay, from the lowest: compound 1; then compounds 4, 3 and 2 (each within the scatter of the next, the first and the last beyond it).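

In this assay, 2-(nitrooxy)phenyl on the carbon with a double bond to nitrogen cannot be told apart from 2,4-dimethoxyphenyl, a 1.2-fold lower number from compound 3 to compound 4 (0.09 log units; within the scatter), yet it does separate from 2,5-dimethoxyphenyl, a 2.3-fold lower number from compound 2 to compound 4 (0.36 log units; beyond the scatter), even though the two dimethoxy isomers lie within the scatter of each other, so the three non-chlorinated aryl groups form a close cluster with only its outer members resolved. The 2,6-dichlorophenyl group of compound 1 stays apart from that cluster, a 3.6-fold higher number from compound 1 to compound 4 (0.56 log units; beyond the scatter), and with this step all three replacements of it give higher numbers, with no compound shown going against that pattern, though a group carrying a different kind of substituent has now joined the two dimethoxy variants. Nothing available here gives a reason for these steps.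

Open, from the compounds shown here alone, is where an unsubstituted phenyl, a 2-chlorophenyl or a 2-hydroxyphenyl would fall, which would show whether one chlorine is enough to approach compound 1 or both are needed. Also open, going by these compounds, is whether an amine or a carboxylic acid on this aryl ring would stay within the cluster or leave it in this assay.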